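Methyl to hydrogen on the five-membered ring: compound 4

This account rests on a few compounds, and the source may have more. Where it says the series, first, only, none or still open, it means among the compounds named here.

Compound 3 `CCc1nc(C)c2n1CCN([C@@H](C(=O)NC)c1ccccc1)C2CCc1ccc(C(F)(F)F)cc1` stands highest of the three numbers in a functional assay on CHO cells for antagonist activity at Orexin/Hypocretin receptor type 1 (Homo sapiens), read by FLIPR and calcium flux (on this read-out higher numbers stand for weaker inhibition and lower numbers for stronger inhibition), at 10000 nM. Compound 1 `CCOc1nc(CC)n2c1C(CCc1ccc(C(F)(F)F)cc1)N([C@@H](C(=O)NC)c1ccccc1)CC2` gives 3980 nM and compound 2 `CCc1nc(OC)c2n1CCN([C@@H](C(=O)NC)c1ccccc1)C2CCc1ccc(C(F)(F)F)cc1` gives 134 nM; the step of a 2.5-fold higher number from compound 1 to compound 3 (0.40 log units; beyond the scatter) is modest and the step of a 75-fold higher number from compound 2 to compound 3 (1.87 log units; beyond the scatter) is large. Compound 4 `CCc1ncc2n1CCN([C@@H](C(=O)NC)c1ccccc1)C2CCc1ccc(C(F)(F)F)cc1` differs from compound 3 by hydrogen in place of methyl on an aromatic carbon. Among the measured compounds shown here, no measured step exchanges methyl for hydrogen at that carbon; both steps reaching compound 3 replace an oxygen-linked group with methyl and therefore give only indirect guidance. Compound 4 is thus expected to lie close to compound 3, with the expected step of a 1.7-fold lower number from compound 3 to compound 4 (0.22 log units; within the scatter) small and uncertain in direction. The estimate for compound 4 is 6000 nM, with a range of 1500 nM to 20000 nM.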

Compound 4, half-maximal inhibitory concentration: 10000 nM
Estimate against measurement, compound 4: 1.7-fold (0.22 log units) below; the measured number falls inside the stated range.
By their numbers in this assay, from the lowest: compound 2; then compound 1; then compounds 3 and 4 (each within the scatter of the next).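

On this aromatic carbon, methyl and hydrogen cannot be told apart: no change at the digits printed from compound 3 to compound 4 (within the scatter). The low number of compound 2 therefore belongs to methoxy rather than to any substituent larger than hydrogen, as a 75-fold higher number from compound 2 to compound 4 (1.87 log units; beyond the scatter) shows, while ethoxy keeps only a much smaller margin, with a 2.5-fold higher number from compound 1 to compound 4 (0.40 log units; beyond the scatter). No evidence available here accounts for these differences.

Open, from the compounds shown here alone, is whether a hydroxyl group or an amine on this carbon would read like methoxy or like hydrogen. Also open, going by these compounds, is whether a methylthio group would retain the low number of compound 2.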